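The compounds below may be only part of what the source reports. "The series", "measured", "known", "first", "only" and "open" are said of these compounds alone.

Working notes on the series. Compound 3 `CC1CCN(CC(=O)O[C@@H]2C[C@@H]3CC[C@@]2(C)C3(C)C)CC1` sits lowest of the three numbers in an ADME assay on MDCK cells (Canis lupus familiaris) for cytotoxicity, read by MTT assay, with a stated time of 48 h (a higher number here means that more compound is tolerated, a lower number that less compound is tolerated), where compound 3 gives 93900 nM; compound 2 `CN1CCN(CC(=O)O[C@@H]2C[C@@H]3CC[C@@]2(C)C3(C)C)CC1` gives 103000 nM, and the gap is a 1.1-fold lower number from compound 2 to compound 3 (0.04 log units; within the scatter). Compound 1 `CC1(C)[C@H]2CC[C@]1(C)[C@H](OC(=O)CN1CCCCC1)C2` gives 138000 nM, separated from compound 3 by a 1.5-fold lower number from compound 1 to compound 3 (0.17 log units; within the scatter). Compound 4 `CC1(C)[C@H]2CC[C@]1(C)[C@H](OC(=O)CN1CCCC1)C2` is the next member and has not yet been measured. The change from compound 3 to compound 4 is pyrrolidin-1-yl in place of 4-methylpiperidin-1-yl on a saturated chain carbon bound to a carbonyl carbon. Among the compounds with values here, three measured steps bear on it: the ring swap at the same place, a 1.3-fold lower number from compound 1 to compound 2 (0.13 log units; within the scatter), the second ring swap at the same place, a 1.1-fold lower number from compound 2 to compound 3 (0.04 log units; within the scatter), and the methyl added on the ring, a 1.5-fold lower number from compound 1 to compound 3 (0.17 log units; within the scatter). All three stay within the scatter, so no step beyond the scatter is expected in this assay in either direction. The expected step is a 1.2-fold higher number from compound 3 to compound 4 (0.07 log units; within the scatter). Compound 4 is estimated at 110000 nM in this assay, with a range from 55000 nM to 220000 nM.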

Compound 4, half-maximal cytotoxic concentration: 302000 nM
Estimate against measurement, compound 4: 2.7-fold (0.44 log units) below; measured number above the stated range.
By their numbers in this assay, from the lowest: compounds 3, 2 and 1 (each within the scatter of the next); then compound 4.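

At the saturated chain carbon bound to a carbonyl carbon, pyrrolidin-1-yl is the first group shown to move this assay beyond the scatter, with more compound tolerated against each of the three six-membered rings (a 3.2-fold higher number from compound 3 to compound 4 (0.51 log units; beyond the scatter); a 2.9-fold higher number from compound 2 to compound 4 (0.47 log units; beyond the scatter); a 2.2-fold higher number from compound 1 to compound 4 (0.34 log units; beyond the scatter)). Piperidin-1-yl, 4-methylpiperidin-1-yl and 4-methylpiperazin-1-yl stay within the scatter of one another, so among these four compounds the only separation at this place lies between the five-membered ring and the six-membered rings. Nothing at hand accounts for this separation.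

Open, as far as these compounds go, is whether azetidin-1-yl or azepan-1-yl at the same place would fall with pyrrolidin-1-yl or with the six-membered rings. Also open, from the compounds shown here alone, is whether a substituted ring such as 3-hydroxypyrrolidin-1-yl would keep the step.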